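A few compounds are considered here, and "the series" means these few. Any claim that something is new, unique, unknown or untested is made for them only; others in the source may bear on it.

Compound 1 `CN1C/C(=C\c2ccc(C#N)cc2)C(=O)/C(=C/c2cccnc2)C1` and compound 2 `CN1C/C(=C\c2ccncc2)C(=O)/C(=C/c2ccc(C#N)cc2)C1` share a core and differ in a single place. The difference is pyridin-4-yl in place of pyridin-3-yl on a double-bonded chain carbon bound to a double-bonded ring carbon. In a functional assay on HepG2 cells (Homo sapiens) for cytotoxicity, read by MTT assay, with a stated time of 24 h (a higher number here means a weaker inhibitor, a lower number a stronger inhibitor), compound 1 gives 12700 nM, and in the same assay compound 2 gives 13900 nM. This gives a step of a 1.1-fold higher number from compound 1 to compound 2 (0.04 log units; within the scatter).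

Compound 3 `O=C1/C(=C/c2cccnc2)CNC/C1=C\c1ccccc1F` belongs to a different core, and the difference between the two cores is not broken down here. In this assay compound 3 gives 21000 nM, which stands within the scatter of both compound 1 and compound 2.

Compound 4 `O=C1/C(=C/c2ccncc2)CNC/C1=C\c1ccccc1F` has not yet been measured. It differs from compound 3 in the same way as compound 2 differs from compound 1, namely (pyridin-4-yl in place of pyridin-3-yl on a double-bonded chain carbon bound to a double-bonded ring carbon), and the place of the change is described in the same words for both pairs, so this is the same change made on another core.

Within the data shown here, the only guide to what the change does is the step from compound 1 to compound 2, which stays within the scatter. Compound 4 is therefore expected to show a step of a 1.0-fold higher number from compound 3 to compound 4 (0.02 log units; within the scatter) in this assay, resting on the value of compound 3, 21000 nM, and on the earlier step of a 1.1-fold higher number from compound 1 to compound 2 (0.04 log units; within the scatter). The estimate for compound 4 in this assay is 22000 nM, with a range from 12000 nM to 40000 nM to allow for the scatter and for the different core.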

Compound 4, half-maximal inhibitory concentration: 8200 nM
For compound 4 the middle estimate is 2.7-fold (0.43 log units) above the measured one, and the stated range ends above it.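

On the core of compound 3, putting pyridin-4-yl in place of pyridin-3-yl on a double-bonded chain carbon bound to a double-bonded ring carbon gives, in this assay, a 2.6-fold lower number from compound 3 to compound 4 (0.41 log units; beyond the scatter), a modest step, and the two steps for this one change do not agree: the same change on two cores in this assay, a 1.1-fold higher number (0.04 log units; within the scatter) from compound 1 to compound 2 and a 2.6-fold lower number (0.41 log units; beyond the scatter) from compound 3 to compound 4, 2.8-fold (0.45 log units) apart, beyond the scatter of two such steps. The change therefore does not carry over unaltered between these two cores, and a step read on the core of compound 1 was not a reliable guide to the step on the core of compound 3. This does not show which feature of the cores accounts for the gap, and with a single pair on each core it gives no general rule for the series.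

The compounds shown leave open whether the gap goes with the nitrile and methyl groups carried by compound 1 and compound 2, or with the fluorine carried by compound 3 and compound 4. They also leave open how a pyridin-2-yl group or a carboxylic acid on the same double-bonded chain carbon would read in this assay, on either core.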